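This account rests on a few compounds, and the source may have more. Where it says the series, first, only, none or still open, it means among the compounds named here.

Compound 1 `CN(C)c1ccc(C(=O)NCc2ccc(NS(C)(=O)=O)cc2Cl)cc1`: 1460 nM
Compound 2 `CS(=O)(=O)Nc1ccc(CNC(=O)c2ccc(N3CCCCC3)cc2)c(Cl)c1`: 410 nM

Among the measured compounds shown here, in an assay on HeLa cells for agonist activity at Bile acid receptor (Homo sapiens), read by a luciferase reporter, with a stated time of 24 h (a lower number here means that less compound is needed, a higher number that more compound is needed for the effect), compound 2 stands at the lower of the two numbers, with compound 1 the only neighbour. Compound 3 `CS(=O)(=O)Nc1ccc(CNC(=O)c2ccc(CC(F)(F)F)cc2)c(Cl)c1` carries a change on the same aromatic carbon: 2,2,2-trifluoroethyl in place of piperidin-1-yl on an aromatic carbon. For the measured compounds named here, the one measured step, a 3.6-fold lower number from compound 1 to compound 2 (0.55 log units; beyond the scatter), also changed this carbon's substituent, so it bears on the new change only loosely; a group without a ring or an acceptor has no precedent here. The number for compound 3 is therefore expected to rise, estimated as a 3.7-fold higher number from compound 2 to compound 3 (0.56 log units; beyond the scatter). Compound 3 is estimated at 1500 nM, within 400 nM to 6000 nM.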

Compound 3, half-maximal effective concentration: 4000 nM
For compound 3 the middle estimate is 2.7-fold (0.43 log units) below the measured one, and the stated range covers the measured number.
By their numbers in this assay, from the lowest: compound 2; then compound 1; then compound 3.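

In this assay, 2,2,2-trifluoroethyl on this aromatic carbon does more than undo the gain from piperidin-1-yl: the change gives a 9.8-fold higher number from compound 2 to compound 3 (0.99 log units; beyond the scatter) and also a 2.7-fold higher number from compound 1 to compound 3 (0.44 log units; beyond the scatter). Among these three compounds, the group with no nitrogen therefore needs the most compound, behind both the ring amine and the open dimethylamino group. No measurement shown explains this loss. Still open, on these data alone, is whether the nitrogen or the fluorine matters more. An all-carbon cyclohexyl ring, a morpholin-4-yl ring or a plain ethyl group could help separate these possibilities.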